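A few compounds are considered here, and "the series" means these few. Any claim that something is new, unique, unknown or untested is made for them only; others in the source may bear on it.

Compound 1 `CCCCn1cc(Cn2nc(N)c3c(C(F)(F)F)cc(-c4ccccc4)nc32)nn1` gives 46.1 ug/mL in a functional assay on THP-1 cells (Homo sapiens) for cytotoxicity, read by MTT assay, with a stated time of 24 h; on this read-out higher numbers stand for weaker inhibition and lower numbers for stronger inhibition.
Compound 2 `Nc1nn(Cc2cn(-c3ccc(O)c([N+](=O)[O-])c3)nn2)c2nc(-c3ccccc3)cc(C(F)(F)F)c12` gives 36.3 ug/mL in this assay.
Compound 3 `Nc1nn(Cc2cn(CC(=O)Nc3ccccc3)nn2)c2nc(-c3ccccc3)cc(C(F)(F)F)c12` gives 54.6 ug/mL in this assay.

Compound 3 is not set apart from the other two beyond the scatter: a 1.2-fold higher number from compound 1 to compound 3 (0.07 log units; within the scatter) and a 1.5-fold higher number from compound 2 to compound 3 (0.18 log units; within the scatter). Compound 4 `COc1ccc(NC(=O)Cn2cc(Cn3nc(N)c4c(C(F)(F)F)cc(-c5ccccc5)nc43)nn2)cc1` differs from compound 3 only by methoxy in place of hydrogen on an aromatic carbon. For the measured compounds named here, no measured step touches this position; the steps that exist, a 1.3-fold lower number from compound 1 to compound 2 (0.10 log units; within the scatter) among them, concern other parts of the molecule and all lie within the scatter. The expectation for this assay is therefore no change beyond the scatter, estimated as a 1.1-fold lower number from compound 3 to compound 4 (0.04 log units; within the scatter). Compound 4 is accordingly estimated at 50 ug/mL, with a range from 25 ug/mL to 100 ug/mL.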

Compound 4, half-maximal inhibitory concentration: 56.7 ug/mL
Compound 4: middle estimate off by 1.1-fold (0.05 log units), on the low side; the measured number falls inside the stated range.
By their numbers in this assay, from the lowest: compounds 2, 1, 3 and 4 (each within the scatter of the next).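

In this assay, methoxy in place of hydrogen, on an aromatic carbon para to a large group, gives a 1.0-fold higher number from compound 3 to compound 4 (0.02 log units; within the scatter), so this first look at the ring of the phenylcarbamoyl group shows no change beyond the scatter. Compound 4 also stays within the scatter of the other two compounds, with a 1.6-fold higher number from compound 2 to compound 4 (0.19 log units; within the scatter) and a 1.2-fold higher number from compound 1 to compound 4 (0.09 log units; within the scatter). Nothing measured here offers an explanation for this result. As far as these compounds go, it remains open whether an amine, a carboxylic acid or a longer chain at this same place would move the number beyond the scatter.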